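Methoxy additions on the styryl ring of two lactone cores

A few compounds are considered here, and "the series" means these few. Any claim that something is new, unique, unknown or untested is made for them only; others in the source may bear on it.

Measured compounds:
compound 1 `O=C1C=COC(/C=C/c2ccccc2)C1` — 58.2 uM
compound 2 `COc1ccc(/C=C/C2CC(=O)C=CO2)cc1` — 87.4 uM
compound 3 `COc1ccc(/C=C/C2CC=CC(=O)O2)cc1OC` — 16.8 uM

In a functional assay on OVCAR-3 cells (Homo sapiens) for inhibition, read by sulforhodamine B assay, with a stated time of 48 h (on this read-out lower numbers stand for stronger inhibition of growth and higher numbers for weaker inhibition of growth), compound 1 gives 58.2 uM and compound 2 gives 87.4 uM. Among the measured compounds shown here, the step of a 1.5-fold higher number from compound 1 to compound 2 (0.18 log units; within the scatter) is the only measured step for the change (methoxy in place of hydrogen on an aromatic carbon). Compound 3 carries a different core; the difference between the two cores is not broken down here. In this assay compound 3 gives 16.8 uM, the lowest of the three numbers, and its distances to compound 1 and compound 2 lie beyond the scatter.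

Compound 4 `COc1cc(OC)c(OC)cc1/C=C/C1CC=CC(=O)O1` is not yet measured. It differs from compound 3 by methoxy in place of hydrogen on an aromatic carbon. This is the same kind of change as that from compound 1 to compound 2, but the place differs: in compound 2 the methoxy sits para to the group of 9 heavy atoms, whereas in compound 4 it sits ortho to that group, meta to a methoxy group and para to a methoxy group. With one earlier step of this kind, which stayed within the scatter, the step of a 1.3-fold higher number from compound 3 to compound 4 (0.12 log units; within the scatter) is expected to be small as well, since a 1.5-fold higher number from compound 1 to compound 2 (0.18 log units; within the scatter) gave little movement. Compound 4 is therefore estimated at 22 uM in this assay, with a range from 9 uM to 55 uM.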

Compound 4, concentration for growth inhibition (reported as GI): 7.2 uM
Compound 4: the middle estimate sits 3.1-fold (0.49 log units) above what was measured; the measured number lies below the stated range.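

In this assay, methoxy in place of hydrogen on an aromatic carbon gives a 2.3-fold lower number from compound 3 to compound 4 (0.37 log units; beyond the scatter), so on this core the change goes with stronger inhibition of growth. The same change does not read the same on the two cores: the same change on two cores in this assay, a 1.5-fold higher number (0.18 log units; within the scatter) from compound 1 to compound 2 and a 2.3-fold lower number (0.37 log units; beyond the scatter) from compound 3 to compound 4, 3.5-fold (0.54 log units) apart, beyond the scatter of two such steps. This shows that the earlier step did not carry over to the second core, but it does not show that the core alone sets the outcome: the two pairs also differ in the place of the entering methoxy, which in compound 4 is ortho to a group of 9 heavy atoms, meta to a methoxy group and para to a methoxy group.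

Open, on these data alone, is whether methoxy at that same place on the core of compound 1 would give a step like the one on the core of compound 3. Also open, as far as these compounds go, is how an amine, a carboxylic acid or a longer chain at that place would compare with methoxy.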